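A few compounds are considered here, and "the series" means these few. Any claim that something is new, unique, unknown or untested is made for them only; others in the source may bear on it.

The shared core of this small series carries a side chain on a sulfur that is bound to a saturated chain carbon. Compound 1 `CCCCCSCCC1C2CCC(O2)C1C/C=C\CCCC(=O)O` holds a pentyl group there; in a functional assay on a cell-free system (plasma) with thromboxane A2 receptor (Homo sapiens) as the target (a higher number here means a weaker inhibitor, a lower number a stronger inhibitor), compound 1 gives 37000 nM. Among the measured compounds shown here, compound 2 `CCCNC(=O)CSCC1C2CCC(O2)C1C/C=C\CCCC(=O)O` replaces that group with (propylcarbamoyl)methyl; in this assay compound 2 gives 72000 nM, the highest of the two numbers so far, with the move a 1.9-fold higher number from compound 1 to compound 2 (0.29 log units; within the scatter) lying within the scatter.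

Compound 3 `O=C(O)CCC/C=C\CC1C2CCC(O2)C1CSc1ccccc1` carries a change on the same sulfur: phenyl in place of (propylcarbamoyl)methyl on a sulfur. For the measured compounds named here, the only measured step, the one from compound 1 to compound 2, bears on it just by showing that changing the group on this sulfur between a plain chain and an amide-bearing chain moved this assay little. Nothing measured here covers an aromatic ring at this place, so the direction of the step is open, and a step no larger than that earlier one is the most defensible expectation; any shift is expected to be modest, with a 2.4-fold lower number from compound 2 to compound 3 (0.38 log units; beyond the scatter). Compound 3 is therefore estimated at 30000 nM in this assay, within a range from 7000 nM to 130000 nM.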

Compound 3, half-maximal inhibitory concentration: 13000 nM
For compound 3 the middle estimate is 2.3-fold (0.36 log units) above the measured one; the range from low to high includes it.
By their numbers in this assay, from the lowest: compound 3; then compounds 1 and 2 (each within the scatter of the next).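

Phenyl on this sulfur produces a change that the earlier pair did not: in this assay there is a 5.5-fold lower number from compound 2 to compound 3 (0.74 log units; beyond the scatter), and the comparison with the pentyl compound gives a 2.8-fold lower number from compound 1 to compound 3 (0.45 log units; beyond the scatter). Both steps lie beyond the scatter, whereas compounds 1 and 2, with their two open chains, stay within the scatter of each other, so the number at this position does depend on the group on the sulfur, and compound 3 is the strongest inhibitor of the three. Both steps are still modest, and no measurement shown here explains why this change lowers the number.

Going by these compounds, one aromatic ring is a single example, so it remains open whether the lower number belongs to the aromatic ring itself or to a compact ring of any kind; a cyclohexyl group on the sulfur would compare a saturated ring of the same size. A benzyl group, or a phenyl ring carrying a chlorine atom or a methoxy group, would show whether the trend continues or reverses beyond plain phenyl.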